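This account rests on a few compounds, and the source may have more. Where it says the series, first, only, none or still open, it means among the compounds named here.

Compound 1 `O=C(Nc1cccc(-n2cc(-c3ccncc3)c(-c3ccc(Cl)c(O)c3)n2)c1)Nc1cccc(C(F)(F)F)c1`: > 32500 nM
Compound 2 `COc1cc(-c2nn(-c3cccc(NC(=O)c4cccc(C(F)(F)F)c4)c3)cc2-c2ccncc2)ccc1Cl`: > 50000 nM

Compound 1 `O=C(Nc1cccc(-n2cc(-c3ccncc3)c(-c3ccc(Cl)c(O)c3)n2)c1)Nc1cccc(C(F)(F)F)c1` was examined in a functional assay on A549 cells (Homo sapiens) for inhibition, read by sulforhodamine B assay, with a stated time of 48 h (a lower number here means that less compound is tolerated, a higher number that more compound is tolerated), and there compound 1 gives only a limit, > 32500 nM. Compound 2 `COc1cc(-c2nn(-c3cccc(NC(=O)c4cccc(C(F)(F)F)c4)c3)cc2-c2ccncc2)ccc1Cl` likewise gives only a limit in this assay, namely > 50000 nM. Among the measured compounds shown here, compound 2 therefore stands at a boundary rather than at a number (the limit of > 50000 nM in this assay, at which 1 of the 2 values shown sits), and the one other value shown is a limit as well (the limit of > 32500 nM in this assay, at which 1 of the 2 values shown sits). For the measured compounds named here, no step between measured compounds that differ in a single place is available, so any view of the move to compound 3 `COc1cc(-c2nn(-c3cccc(NC(=O)Nc4cccc(C(F)(F)F)c4)c3)cc2-c2ccncc2)ccc1Cl` rests on the structural change alone: (3-(trifluoromethyl)phenyl)amino in place of 3-(trifluoromethyl)phenyl on a carbonyl carbon. Compound 1 already carries (3-(trifluoromethyl)phenyl)amino on a carbonyl carbon and sits at its limit, so no shift beyond the scatter is expected in this assay. The step from compound 2 to compound 3 is expected to be about a step that the limit leaves unreadable from compound 2 to compound 3. Compound 3 is estimated at 60000 nM, within 25000 nM to 150000 nM, most likely again reported only as a limit.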

Compound 3, concentration lethal to 50% of the cells: > 50000 nM
Compound 3: no number, only a limit (the forecaster's own chance of this, stated with the estimate: 85%); the middle value lies beyond the limit too.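

In this assay compound 3 gives only a limit, > 50000 nM. Among the compounds shown here, compound 1 and compound 2 also give only limits, so no step to compound 3 from either can be read. The compounds shown leave open whether (3-(trifluoromethyl)phenyl)amino in place of 3-(trifluoromethyl)phenyl on a carbonyl carbon, or methyl in place of hydrogen on the oxygen, changes the result in this assay at all.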